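A few compounds are considered here, and "the series" means these few. Any claim that something is new, unique, unknown or untested is made for them only; others in the source may bear on it.

Compound 2 `N#CC1=C(/N=C/Nc2ccc([N+](=O)[O-])cc2)N(c2ccccc2)C(=O)N2CCCCC(N3CCCC3)C12` holds the lowest of the three numbers shown in a functional assay on the whole organism (strain albino) for inhibition, with Rattus norvegicus as the target, read by paw edema, with stated times of 1 h and 3 h, at a dose of 20 mmol/kg by the intraperitoneal route (a higher number here means a stronger effect of the compound at the dose given, a lower number a weaker effect), where compound 2 gives 85.6%. Compound 3 `COC(=O)C(=O)NC1=C(C#N)C2C(N3CCCC3)CCCCN2C(=O)N1c1ccccc1` is nearest, giving 88.3%, and compound 1 `N#CC1=C(NCC(=O)O)N(c2ccccc2)C(=O)N2CCCCC(N3CCCC3)C12` furthest, giving 89.2%, both gaps lying within the scatter. Compound 4 `N#CC1=C(N)N(c2ccccc2)C(=O)N2CCCCC(N3CCCC3)C12` arises from compound 2 by the change (one nitrogen atom in place of a group of 12 heavy atoms (7 carbon, 3 nitrogen, 2 oxygen; one six-membered aromatic ring of carbon only), on a double-bonded ring carbon). Going by the values given here, two measured steps bear on it, since each exchanges the group on a double-bonded ring carbon: a number 3.6 percentage points lower from compound 1 to compound 2 (within the scatter) and a number 2.7 percentage points higher from compound 2 to compound 3 (within the scatter). Neither reached beyond the scatter, so in this assay no step beyond the scatter is expected, though amino has not been tried at that place, which widens the range. Compound 4 is therefore estimated at 82%, between 65% and 92%, expected as a number 3.6 percentage points lower from compound 2 to compound 4 (within the scatter).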

Compound 4, a percentage reported as inhibition, in the whole organism at one dose (the size of the read-out at that dose, not a potency): 90.1%
Compound 4: middle estimate off by 8.1 percentage points, on the low side; the range from low to high includes it.
By their numbers in this assay, from the lowest: compounds 2, 3, 1 and 4 (each within the scatter of the next).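

In this assay, amino on the double-bonded ring carbon gives a number 4.5 percentage points higher from compound 2 to compound 4 (within the scatter) and a number 1.8 percentage points higher from compound 3 to compound 4 (within the scatter) and a number 0.9 percentage points higher from compound 1 to compound 4 (within the scatter). So the much smaller group stands level with all three larger groups, and none of those larger groups is shown to be needed at this place for the effect at this dose. Nothing measured here explains this result. The compounds shown leave open whether methylamino, a longer chain on the amine nitrogen, or hydroxyl in place of amino would also stay within the scatter.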